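The source may report more compounds than this note shows. Statements on the series, on what has been measured and on what is new or still open speak of the compounds shown alone.

Measured compounds
- Compound 1 `COc1cc2oc(-c3cccc(NC(=O)c4ccc(Cl)cc4)c3)cc(=O)c2c(OC)c1OC`: 51.1%
- Compound 2 `COc1cc2oc(-c3ccc(NC(=O)c4ccc(Br)cc4)cc3)cc(=O)c2c(OC)c1OC`: "active" (no number reported)
- Compound 3 `COC(=O)c1ccc(C(=O)Nc2ccc(-c3cc(=O)c4c(OC)c(OC)c(OC)cc4o3)cc2)cc1`: "active" (no number reported)

Within the data shown here, in a functional assay on UO-31 cells (Homo sapiens) for inhibition, read by sulforhodamine B assay, tested at 10 uM (on this read-out lower numbers stand for less inhibition and higher numbers for more inhibition at the one concentration tested (going by the name of the read-out)), compound 1 gives 51.1%; this is the only number in the set. Among the measured compounds shown here, compound 2 is reported in this assay as "active" (no number reported) and compound 3 as "active" (no number reported), both without a figure, so no step between measured compounds can be given and compound 1 cannot be ranked against them. Whether the number in this assay is higher, lower or level with the amide in either orientation is therefore not shown.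

Compound 4 `COc1cc2oc(-c3cccc(C(=O)Nc4ccc(Cl)cc4)c3)cc(=O)c2c(OC)c1OC` has not been measured. It differs from compound 1 as follows: (4-chlorophenyl)carbamoyl in place of ((4-chlorophenyl)carbonyl)amino on an aromatic carbon. The same atoms are joined differently; the amide that links the chlorophenyl group to the shared core is turned round, with the carbonyl now on the core side and the nitrogen on the chlorophenyl side, in the position described as meta to a large group.

For the measured compounds named here, no measured pair in the set shows the effect of such a reversal, so the direction of the step is open. The step from compound 1 to compound 4 in this assay is expected to stay within the usual scatter, a number 4.1 percentage points lower from compound 1 to compound 4 (within the scatter). Compound 4 is estimated at 47%, with a range of 22% to 70%.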

Compound 4, a percentage reported as inhibition, at one concentration (the size of the read-out at that concentration, not a potency): 61.4%
Beside the measured number, compound 4's estimate is 14.4 percentage points below it, within the range that was stated.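

In this assay, turning the amide round, so that (4-chlorophenyl)carbamoyl stands in place of ((4-chlorophenyl)carbonyl)amino on an aromatic carbon meta to a large group, gives a number 10.3 percentage points higher from compound 1 to compound 4 (beyond the scatter). Among these compounds, this is the first pair that differs in one place, and it shows that the direction of the amide at this position matters for this read-out, even though the leaving and entering groups have the same atoms and the same counts of hydrogen-bond donors and acceptors. Nothing at hand bears on why the direction of the amide changes the number.

Going by these compounds, compounds 2 and 3 are recorded only as active, without a figure, so steps to them cannot be read, and it stays open whether reversing the amide would move the number the same way with the amide elsewhere on the ring. Also open, on these data alone, is whether the higher number of the carbamoyl orientation would hold with a sulfonamide as the link, with a longer chain between the amide and the aromatic ring, or with an amine in place of the chlorine.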